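Working notes: substituted-aryl analogues of one lactam core

The compounds below may be only part of what the source reports. "The series", "measured", "known", "first", "only" and "open" are said of these compounds alone.

Measured so far:
compound 1, `O=C1C=CC(OCC(F)(F)F)N1c1cc(Cl)cc(Cl)c1` — 1630 nM
compound 2, `O=C1C=CC(OCC(F)(F)F)N1c1ccc([N+](=O)[O-])cc1` — 3270 nM
compound 3, `O=C1C=CC(OCC(F)(F)F)N1c1ccc(Cl)cc1F` — 6630 nM

All three were run in a functional assay on A549 cells (Homo sapiens) for inhibition; a lower number here means a stronger inhibitor, a higher number a weaker inhibitor. Compound 2 stands second highest of the three numbers. Its nearest neighbour is compound 1, whose value lies within the scatter of it, so no order can be read between those two; compound 3 lies beyond the scatter on the higher side. No two of the measured compounds differ in one place only, so the three values together show nothing more than a narrow band in which the shared core with a substituted phenyl sits.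

Compound 4, `O=C1C=CC(OCC(F)(F)F)N1c1ccc(Br)cc1`, is not yet measured. It differs from compound 2 by bromo in place of nitro on an aromatic carbon. For the measured compounds named here, no measured pair shows what an exchange of this kind does, so the expectation can rest only on the band spanned by compounds 1 to 3. The step of a 1.3-fold lower number from compound 2 to compound 4 (0.12 log units; within the scatter) in this assay is expected to be small, toward a somewhat lower number, and not beyond the scatter. Compound 4 is therefore estimated to give 2500 nM in this assay, with a range from 800 nM to 8000 nM.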

Compound 4, half-maximal inhibitory concentration: 6960 nM
Compound 4: the middle estimate sits 2.8-fold (0.44 log units) below what was measured, and the stated range covers the measured number.
By their numbers in this assay, from the lowest: compounds 1 and 2 (each within the scatter of the next); then compounds 3 and 4 (each within the scatter of the next).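

In this assay, for the compounds shown here, the exchange of nitro for bromo on the aromatic carbon para to a large group gives the first comparison that differs in one place: a 2.1-fold higher number from compound 2 to compound 4 (0.33 log units; beyond the scatter) is a modest move toward weaker inhibition. With the rest of the molecule unchanged, the group at this position therefore affects the read-out, and nitro gives the stronger inhibition of this pair. No available measurement explains the direction or size of this step.

As far as these compounds go, whether an amine, a carboxylic acid or a methoxy group at this position would fall near nitro, near bromo or outside that pair remains open. A single exchange also leaves open whether bromo in place of nitro would give a similar step with a different group elsewhere on the aromatic ring.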